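Aryl ether and ketone variants on the shared core

The source may hold more compounds than are shown below. What is called first, only, known or untested is meant among the compounds shown, and "the series" means these compounds.

Measured so far:
compound 1 `O=C(CSc1nc(Cc2c(F)cccc2F)cc(=O)[nH]1)c1ccc([N+](=O)[O-])cc1` — 22000 nM
compound 2 `Cc1ccc(CSc2nc(Cc3c(F)cccc3F)c(C)c(=O)[nH]2)c(C)c1` — > 65000 nM

In an ADME assay on MT4 cells (Homo sapiens) for cytotoxicity, read by MTT assay (a lower number here means that less compound is tolerated, a higher number that more compound is tolerated), compound 1 gives 22000 nM. For compound 2 this assay returns only a limit, > 65000 nM, so its true value is not known; (the limit of > 65000 nM in this assay, at which 1 of the 2 values shown sits). The two values therefore cannot be compared as a step in this assay.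

Compound 3 `Cc1c(Cc2c(F)cccc2F)nc(SCC(=O)c2ccccc2)[nH]c1=O` is not yet measured. It differs from compound 2 by benzoyl in place of 2,4-dimethylphenyl on a saturated chain carbon bound to a sulfur. Compound 1 also carries a benzoyl on that chain carbon and sits below the limit, so the change is read as a moderate move from compound 2 toward compound 1 rather than none at all. The expected step is an at least 1.4-fold lower number from compound 2 to compound 3 (0.15 log units; that floor lies within the scatter), a decrease of modest size in this assay. For compound 3 the estimate is 45000 nM, within a range from 15000 nM to 110000 nM.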

Compound 3, half-maximal cytotoxic concentration: 65000 nM
For compound 3 the middle estimate is 1.4-fold (0.16 log units) below the measured one; measured number inside the range.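

In this assay compound 3 gives a measured number, 65000 nM, so benzoyl on a saturated chain carbon bound to a sulfur yields a readable value at this position. Compound 2 gives only a limit, > 65000 nM. The data give a number no higher from compound 2 to compound 3 (the limit leaves the size open), and the change from 2,4-dimethylphenyl to benzoyl may amount to a real decrease or to none at all: the limit of > 65000 nM in this assay, at which 1 of the 3 values shown sits.

Going by these compounds, whether the carbonyl or the loss of the two methyl groups matters more at this position stays open. Also open, on these data alone, is how this assay responds to a longer chain in place of benzoylmethyl, or to a carboxylic acid or an amine on the phenyl ring of benzoyl.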